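Two ring stereocentres flipped in a long-lasting compound

The compounds below may be only part of what the source reports. "The series", "measured", "known", "first", "only" and "open" are said of these compounds alone.

Compound 1 `O=C(N[C@H](CO)C(=O)O)[C@@H]1C[C@H](O)CN1`: > 12 h
Compound 2 `O=C(O)[C@H](CO)NC(=O)[C@H]1C[C@@H](O)CN1`: > 12 h

In a physicochemical assay for metabolic stability, read by HPLC, with a stated time of 12 h, at pH 4.5 (a higher number here means that the compound lasts longer, a lower number that the compound disappears faster), compound 2 gives > 12 h, which is a limit and not a number. Compound 1 gives > 12 h, also a limit. Among the compounds with values here, the only measured step is a step that the two limits leave unreadable from compound 1 to compound 2, so it offers no size to build on, although it inverts every stereocentre. Compound 3 `O=C(O)[C@H](CO)NC(=O)[C@@H]1C[C@H](O)CN1` comes next: the two compounds have the same atoms and bonds and differ only in configuration as drawn: 2 of 3 stereo elements differ; a stereocentre at a saturated ring carbon is drawn R in compound 2 and S in compound 3; a stereocentre at a saturated ring carbon is drawn R in compound 2 and S in compound 3. With no readable step as a guide, no change beyond the scatter is expected in this assay, and no direction can be given. The expected step is a step that the limit leaves unreadable from compound 2 to compound 3. For compound 3 the estimated half-life is 24 h, with an expected range of 12 h to 48 h.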

Compound 3, half-life: > 12 h
Compound 3 ended at the assay's limit (the forecaster's own chance of this, stated with the estimate: 85%); the middle value lies beyond the limit too.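

No step between compound 1, compound 2 and compound 3 can be read in this assay: the limit of > 12 h in this assay, at which 3 of the 3 values shown sit.

On these data alone, how long each compound actually lasts, and whether changing the configuration alters that, remains open.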